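The compounds below may be only part of what the source reports. "The series", "measured", "known", "first", "only" and "open" are said of these compounds alone.

Measured compounds:

Compound 1, `Cc1ccc2nc(C(=O)Nc3c(F)cc(-c4cccc(F)c4)cc3F)c(C)c(C(=O)O)c2c1`: -1.05%
Compound 2, `COc1ccc2nc(C(=O)Nc3c(F)cc(-c4cccc(F)c4)cc3F)c(C)c(C(=O)O)c2c1`: 0.05%

Both numbers come from a functional assay on A-375 cells (Homo sapiens) for antiproliferative activity, read by MTT assay, with a stated time of 24 h, tested at 0.01 ug/mL; on this read-out lower numbers stand for a weaker effect and higher numbers for a stronger effect at the one concentration tested. Compound 1 and compound 2 share one core and differ only in one group on the fused ring system; both sit close to zero inhibition. Compound 2 is one of two compounds whose numbers lie within the scatter of each other: the step of a number 1.1 percentage points higher from compound 1 to compound 2 (within the scatter) is too small to mark any real difference, so neither compound can be called the more active.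

Compound 3, `Cc1c(C(=O)Nc2c(F)cc(-c3cccc(F)c3)cc2F)nc2ccc(C(F)(F)F)cc2c1C(=O)O`, is the next compound and is not yet measured. Compared with compound 2 the change is trifluoromethyl in place of methoxy on an aromatic carbon.

For the measured compounds named here, only one measured step exists, the exchange of methyl for methoxy at the same place, and it stayed within the scatter. Going by the values given here, no measured pair swaps methoxy for trifluoromethyl, so nothing bears directly on this step. Among the compounds with values here, with both measured compounds near zero and the only step flat, the expected step from compound 2 to compound 3 in this assay is a number 1 percentage points higher from compound 2 to compound 3 (within the scatter), that is, none beyond the scatter. Compound 3 is therefore estimated at 1%, within a range from -10% to 12%.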

Compound 3, a percentage reported as inhibition, at one concentration (the size of the read-out at that concentration, not a potency): 0.12%
The estimate for compound 3 lay 0.9 percentage points above the measured number; the measured number falls inside the stated range.
By their numbers in this assay, from the lowest: compounds 1, 2 and 3 (each within the scatter of the next).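

In this assay, trifluoromethyl in place of methoxy on this aromatic carbon (a number 0.1 percentage points higher from compound 2 to compound 3 (within the scatter)) and trifluoromethyl in place of methyl (a number 1.2 percentage points higher from compound 1 to compound 3 (within the scatter)) both stay within the scatter. The position has now carried three different groups, and the swap from methoxy to trifluoromethyl, which removes a hydrogen-bond acceptor and brings in more heavy atoms, leaves no visible mark on this read-out, so methyl, methoxy and trifluoromethyl cannot be told apart here. No outside measurement is available to help interpret this flat result.

Going by these compounds, all three compounds sit near zero inhibition at a single concentration, so these numbers cannot separate a position that truly tolerates different groups from a series that simply shows no effect at this dose, and any difference between the groups at higher concentrations remains unknown. On these data alone, it also remains open how an amine, a nitrile or a longer chain such as ethoxy would behave at this place, and whether a change elsewhere on the shared core would move the read-out at all.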